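A few compounds are considered here, and "the series" means these few. Any claim that something is new, unique, unknown or untested is made for them only; others in the source may bear on it.

Working notes on the amine end of the side chain, with the shared core held constant. In a functional assay on SK-BR-3 cells (Homo sapiens) for antiproliferative activity (on this read-out lower numbers stand for stronger inhibition and higher numbers for weaker inhibition), compound 1 (`CC(C)=CCc1cc(C(=O)Nc2cc3ccc(OCCCN4CCCC4)c(C)c3oc2=O)ccc1O`) gives 720 nM with pyrrolidin-1-yl, compound 2 (`CC(C)=CCc1cc(C(=O)Nc2cc3ccc(OCCCNC(C)C)c(C)c3oc2=O)ccc1O`) gives 750 nM with isopropylamino and compound 3 (`CC(C)=CCc1cc(C(=O)Nc2cc3ccc(OCCCNCCO)c(C)c3oc2=O)ccc1O`) gives 610 nM with (2-hydroxyethyl)amino. Compound 3 therefore stands level with the other two amines. The steps among the first two comparisons read a 1.0-fold higher number from compound 1 to compound 2 (0.02 log units; within the scatter) and a 1.2-fold lower number from compound 1 to compound 3 (0.07 log units; within the scatter) and neither leaves the scatter.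

The next change leads to compound 4 (`CC(C)=CCc1cc(C(=O)Nc2cc3ccc(OCCCNCc4ccccc4)c(C)c3oc2=O)ccc1O`) and reads phenyl in place of hydroxymethyl on a saturated chain carbon bound to an amine nitrogen or in words phenyl in place of hydroxymethyl on a saturated chain carbon bound to an amine nitrogen. Among the measured compounds shown here, no measured compound carries an aromatic ring at this place, so the data cover the change only indirectly. The closest measured comparison is a 1.2-fold lower number from compound 2 to compound 3 (0.09 log units; within the scatter) which also exchanges the group on the amine nitrogen. All three steps are small, so no shift beyond the scatter is expected in this assay and the range is kept wide for the untested ring. The estimated change is a 1.1-fold higher number from compound 3 to compound 4 (0.03 log units; within the scatter) in this read-out. Compound 4 is expected at 650 nM with an estimated range from 300 nM to 1400 nM in this read-out.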

Compound 4, half-maximal inhibitory concentration: 470 nM
Beside the measured number, compound 4's estimate is 1.4-fold (0.14 log units) above it; measured number inside the range.
By their numbers in this assay, from the lowest: compounds 4, 3, 1 and 2 (each within the scatter of the next).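

In this assay the exchange of hydroxymethyl for phenyl reads a 1.3-fold lower number from compound 3 to compound 4 (0.11 log units; within the scatter) and shows that an aromatic ring can stand on the saturated chain carbon bound to an amine nitrogen while the number stays within the scatter. Against the other two amines, the steps read a 1.6-fold lower number from compound 2 to compound 4 (0.20 log units; within the scatter) and a 1.5-fold lower number from compound 1 to compound 4 (0.19 log units; within the scatter) and also stay within the scatter, so benzyl on the amine nitrogen and benzylamino on the chain leave compound 4 level with compound 2 and compound 1 in this read-out. No measurement at hand offers a reason for these small steps.

The compounds shown leave open whether a chlorine atom or a methoxy group on the phenyl ring, or a longer chain carrying the phenyl, as in 2-phenylethyl on the amine nitrogen, would move the number beyond the scatter. They also leave open whether a carboxylic acid at the amine end, or an amide in place of the amine, would keep the number level with compound 4.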